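This account rests on a few compounds, and the source may have more. Where it says the series, first, only, none or still open, it means among the compounds named here.

In a functional assay on HCT-116 cells (Homo sapiens) for antiproliferative activity, read by luminescence, with a stated time of 72 h, tested at 1 uM (a higher number here means a weaker inhibitor, a lower number a stronger inhibitor), the three measured compounds give these numbers:

compound 1 `Cc1cc(Nc2nc(SCc3ccc(C(=O)Nc4ccccc4N)cc3)nn3cccc23)n[nH]1`: 959 nM
compound 2 `Cc1cccnc1Nc1nc(SCc2ccc(C(=O)Nc3ccccc3N)cc2)nn2cccc12`: 1370 nM
compound 3 `Cc1cc(Nc2nc(SCc3ccc(C(=O)Nc4ccc(F)cc4N)cc3)nn3cccc23)n[nH]1`: 75.1 nM

Compound 3 stands lowest of the three, with a 13-fold lower number from compound 1 to compound 3 (1.11 log units; beyond the scatter), a large step that came from a single fluoro in place of hydrogen on an aromatic carbon; the number for compound 2 lies further away still. Compound 4 `COc1ccc(CNc2nc(SCc3ccc(C(=O)Nc4ccc(F)cc4N)cc3)nn3cccc23)cc1` keeps that fluoro and alters the other end: 4-methoxybenzyl in place of 5-methyl-1H-pyrazol-3-yl on a nitrogen on an aromatic ring. Among the compounds with values here, only one measured step touches this position, a 1.4-fold higher number from compound 1 to compound 2 (0.15 log units; within the scatter), where the pyrazolyl was swapped for a different ring and the number barely moved. Within the data shown here, that is the sole guide, and the group entering here is larger and unlike either ring, so the guide is weak. The expectation is therefore a small step, a 2.1-fold higher number from compound 3 to compound 4 (0.33 log units; beyond the scatter), not clearly beyond the scatter in either direction, with wide uncertainty. Compound 4 is estimated at 160 nM, within a range from 40 nM to 700 nM in this assay.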

Compound 4, half-maximal inhibitory concentration: 997 nM
Compound 4: middle estimate off by 6.2-fold (0.79 log units), on the low side; measured number outside the range, above it.
By their numbers in this assay, from the lowest: compound 3; then compounds 1, 4 and 2 (each within the scatter of the next).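

In this assay, the step of a 13-fold higher number from compound 3 to compound 4 (1.12 log units; beyond the scatter) shows that the group on this nitrogen can matter a great deal, something the earlier ring swap, a 1.4-fold higher number from compound 1 to compound 2 (0.15 log units; within the scatter), gave no sign of. This change replaces a five-membered aromatic ring with 2 hetero atoms and 1 hydrogen-bond donor by 4-methoxybenzyl, with its six-membered carbon-only ring, 9 heavy atoms and 0 hydrogen-bond donors, and a single step cannot separate these differences from one another. Nothing available here gives a reason for this large step.

Still open is which part of 4-methoxybenzyl carries the step: would a plain benzyl, with no methoxy, or a phenyl attached directly to the nitrogen give a number closer to that of compound 3? Going by these compounds, it is also open whether 3-methylpyridin-2-yl would stay level with 5-methyl-1H-pyrazol-3-yl when the fluoro is present.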